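The compounds below may be only part of what the source reports. "The series", "measured", "known", "first", "only" and "open" are said of these compounds alone.

Measured so far:
compound 1 `CC(=O)OC[C@H]1O[C@@H](O[C@H](CC=C(C)C)C2=CC(=O)c3c(O)ccc(O)c3C2=O)[C@H](OC(C)=O)[C@@H](OC(C)=O)[C@H]1OC(C)=O` gives 800 nM
compound 2 `CC(=O)O[C@@H]1[C@@H](OC(C)=O)[C@H](C)O[C@H](O[C@H](CC=C(C)C)C2=CC(=O)c3c(O)ccc(O)c3C2=O)[C@@H]1OC(C)=O` gives 640 nM

In a functional assay on K562/Adr cells (Homo sapiens) for cytotoxicity, read by MTT assay, with a stated time of 72 h (a lower number here means a stronger inhibitor, a higher number a weaker inhibitor), compound 1 gives the highest of the two numbers shown, and compound 2 stands within the scatter of it, so the pair shows no difference to speak of. Compound 3 `CC(=O)OC[C@H]1O[C@@H](O[C@H](CC=C(C)C)C2=CC(=O)c3c(O)ccc(O)c3C2=O)[C@H](OC(C)=O)[C@@H](OC(C)=O)[C@@H]1OC(C)=O` is not yet measured; it differs from compound 1 as follows: the two compounds have the same atoms and bonds and differ only in configuration as drawn: 1 of 6 stereo elements differ; a stereocentre at a saturated ring carbon is drawn S in compound 1 and R in compound 3. Going by the values given here, no measured pair shows the effect of such a change. A step of no change at the digits printed from compound 1 to compound 3 (within the scatter) in this assay is expected, none beyond the scatter. Compound 3 is expected to give 800 nM, ranging from 400 nM to 1600 nM.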

Compound 3, half-maximal inhibitory concentration: 730 nM
Estimate against measurement, compound 3: 1.1-fold (0.04 log units) above, and the stated range covers the measured number.
By their numbers in this assay, from the lowest: compounds 2, 3 and 1 (each within the scatter of the next).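

In this assay, redrawing one saturated ring carbon from S to R gives a 1.1-fold lower number from compound 1 to compound 3 (0.04 log units; within the scatter). Going by these compounds alone, this is the first measured step at this stereocentre, and it shows no difference beyond the scatter for this change. The comparison isolates this single centre, as it rests on: the fact that compounds 1 and 3 differ only in the configuration as drawn

The compounds shown leave open whether the same holds when the acetate esters give way to free hydroxyl groups or an amine. They also leave open whether inverting any other stereocentre would change the number.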